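Amide aryl variation and rat clearance in the series

The source may report more compounds than this note shows. Statements on the series, on what has been measured and on what is new or still open speak of the compounds shown alone.

Measured so far:
compound 1 `C[C@@]1(c2cc(NC(=O)c3coc(CF)n3)ccc2F)C=C(CF)OC(N)=N1`, 55 mL/min/kg
compound 2 `C[C@@]1(c2cc(NC(=O)c3cnc(OCF)cn3)ccc2F)C=C(CF)OC(N)=N1`, 34.4 mL/min/kg

In an ADME assay on the whole organism (strain Sprague-Dawley) for pharmacokinetics, with Rattus norvegicus as the target, read by LC-MS, using cassette dosing, at a dose of 0.5 mg/kg by the intravenous route (on this read-out lower numbers stand for slow clearance and higher numbers for fast clearance), compound 1 gives 55 mL/min/kg, the highest of the two numbers, with compound 2 the nearest at 34.4 mL/min/kg. Within the data shown here, the only step yet measured exchanges the amide aryl group: a 1.6-fold lower number from compound 1 to compound 2 (0.20 log units; within the scatter). Compound 3 `Cc1cc(C#N)cnc1C(=O)Nc1ccc(F)c([C@]2(C)C=C(CF)OC(N)=N2)c1` is the next change at the same place: 5-cyano-3-methylpyridin-2-yl in place of 2-(fluoromethyl)-1,3-oxazol-4-yl on a carbonyl carbon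

Among the measured compounds shown here, no measured step covers this particular group, and the one step at the same position, from compound 1 to compound 2, stayed within the scatter. Nothing here therefore argues for a shift in either direction beyond the scatter, though the absence of any step for this group leaves the range wide. Compound 3 is expected to give 45 mL/min/kg in this assay, between 22 mL/min/kg and 90 mL/min/kg, that is an estimated 1.2-fold lower number from compound 1 to compound 3 (0.09 log units; within the scatter).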

Compound 3, clearance: 21.8 mL/min/kg
For compound 3 the middle estimate is 2.1-fold (0.31 log units) above the measured one, outside the stated range (below it).
By their numbers in this assay, from the lowest: compounds 3, 2 and 1 (each within the scatter of the next, the first and the last beyond it).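

In this assay the amide aryl position now gives its first step beyond the scatter, though a modest one: 5-cyano-3-methylpyridin-2-yl in place of 2-(fluoromethyl)-1,3-oxazol-4-yl on the carbonyl carbon gives (a 2.5-fold lower number from compound 1 to compound 3 (0.40 log units; beyond the scatter)). The exchange of 5-(fluoromethoxy)pyrazin-2-yl for 5-cyano-3-methylpyridin-2-yl stays within the scatter (a 1.6-fold lower number from compound 2 to compound 3 (0.20 log units; within the scatter)), so these two groups are not told apart on this read-out. No measurement shown gives a reason for either step.

The compounds shown do not separate the contribution of the nitrile from that of the methyl in 5-cyano-3-methylpyridin-2-yl. From the compounds shown here alone, how a plain phenyl group or an aryl group carrying an amine on the same carbonyl carbon would read in this assay also stays open.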